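This account rests on a few compounds, and the source may have more. Where it says the series, first, only, none or still open, it means among the compounds named here.

Measured compounds:
- Compound 1, `CC(C)(C)Oc1cc(O)c2c(=O)cc(-c3ccc(O)cc3)oc2c1`: 25 ug/mL
- Compound 2, `O=c1cc(-c2ccccc2)oc2cc(OCc3ccc(F)cc3)cc(O)c12`: 8.35 ug/mL

In an ADME assay on C8166 cells (Homo sapiens) for inhibition, read by MTT assay, with a stated time of 72 h (a higher number here means that more compound is tolerated, a lower number that less compound is tolerated), compound 1 gives 25 ug/mL, while compound 2 gives 8.35 ug/mL. Compound 2 thus stands lowest of the two values available, and the gap to compound 1 lies beyond the usual scatter, so compound 2 is the less well tolerated of the pair.

Compound 3, `CC(C)(C)Oc1cc(O)c2c(=O)cc(-c3ccccc3)oc2c1`, has not yet been measured. It differs from compound 2 in one place: tert-butyl in place of 4-fluorobenzyl on an oxygen on an aromatic ring. For the measured compounds named here, the entering tert-butoxy group is the same group that compound 1 carries on its oxygen, although compound 3 and compound 1 are not otherwise identical and no step between them is given.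

Since compound 1, the tert-butoxy bearer, gives 25 ug/mL, compound 3 is expected to sit higher than compound 2, with a step upward in this assay of moderate size, probably beyond the scatter. The expected step is a 2.2-fold higher number from compound 2 to compound 3 (0.33 log units; beyond the scatter). Compound 3 is estimated at 18 ug/mL, within a range from 8 ug/mL to 40 ug/mL.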

Compound 3, half-maximal cytotoxic concentration: 61.2 ug/mL
Estimate against measurement, compound 3: 3.4-fold (0.53 log units) below; the measured number lies above the stated range.
By their numbers in this assay, from the lowest: compound 2; then compound 1; then compound 3.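

In this assay, tert-butyl in place of 4-fluorobenzyl on an oxygen on an aromatic ring gives a 7.3-fold higher number from compound 2 to compound 3 (0.87 log units; beyond the scatter) and so provides a reading of this change alone, which compounds 1 and 2 could not give, since they differ in more than one place. The tert-butoxy compounds also show that the other place matters in this assay: hydrogen in place of hydroxy on an aromatic carbon gives a 2.4-fold higher number from compound 1 to compound 3 (0.39 log units; beyond the scatter) and so, with the tert-butoxy group held constant, it is the compound without the hydroxy group that is the better tolerated. Nothing available explains either step.

The compounds shown leave open which part of the departing 4-fluorobenzyl group goes with the lower number, the fluorine or the aromatic ring, and a plain benzyl, a methyl or a longer chain on the same oxygen would begin to separate these. They also leave open whether the same change would give a step of similar size with the hydroxy group in place, and how an amine or a carboxylic acid at this oxygen would read.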